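Compound 1 and a hydroxymethyl analogue

The compounds below may be only part of what the source reports. "The series", "measured", "known", "first", "only" and "open" are said of these compounds alone.

Measured so far in a functional assay on HepG2 cells (Homo sapiens) for inhibition, read by MTT assay, with a stated time of 72 h, tested at 50 uM; on this read-out higher numbers stand for more inhibition of growth at the one concentration tested and lower numbers for less inhibition of growth
- compound 1 `C=CCc1cc(O)c(O)c(CN2CCC(C)CC2)c1` gives 69.7%
- compound 2 `C=CCc1ccc(OCc2cn(-c3cccc(C#N)c3)nn2)c(O)c1` gives 3.4%

Compound 1 stands highest of the two measured compounds, and the gap down to compound 2 lies beyond the scatter. Compound 3 `C=CCc1cc(O)c(O)c(CN2CCC(CO)CC2)c1` departs from compound 1 by one change, hydroxy in place of hydrogen on a saturated chain carbon bound to a saturated ring carbon with hydroxy in place of hydrogen on a saturated chain carbon bound to a saturated ring carbon. Among the compounds with values here, no measured pair differs in one place only, so the data offer no direct guide. A small fall in this assay is expected, not clearly beyond the scatter, and the estimated size is a number 9.7 percentage points lower from compound 1 to compound 3 (within the scatter) at most loosely known. Compound 3 is estimated at 60% (35% to 80%).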

Compound 3, percent growth inhibition at one concentration: 5.4%
The estimate for compound 3 lay 54.6 percentage points above the measured number, outside the stated range (below it).
By their numbers in this assay, from the lowest: compounds 2 and 3 (each within the scatter of the next); then compound 1.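

In this assay, within the data shown here, the change from methyl to hydroxymethyl, on a saturated chain carbon bound to a saturated ring carbon, brings a number 64.3 percentage points lower from compound 1 to compound 3 (beyond the scatter) and is the first single change seen in this set. This place on the core of compound 1 therefore does not accept every small change: one added oxygen is enough to take away nearly all of the inhibition of growth. No measurement at hand accounts for this fall. Going by these compounds, whether an aminomethyl, a methoxymethyl or a longer alkyl chain in place of the methyl would keep the number of compound 1 stays open.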